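Amino Substitution on Two Nucleoside Cores: Antiproliferative Outlook

This account rests on a few compounds, and the source may have more. Where it says the series, first, only, none or still open, it means among the compounds named here.

Measured so far in a functional assay on HepG2 cells (Homo sapiens) for antiproliferative activity, read by XTT assay, with a stated time of 72 h; on this read-out higher numbers stand for weaker inhibition and lower numbers for stronger inhibition:
compound 1 `COc1ncnc2c1c(-c1cccs1)cn2[C@@H]1O[C@H](CO)[C@@H](O)[C@H]1O` — compound 1 gives 13900 nM
compound 2 `COc1nc(N)nc2c1c(-c1cccs1)cn2[C@@H]1O[C@H](CO)[C@@H](O)[C@H]1O` — compound 2 gives > 20000 nM
compound 3 `O=c1[nH]cnc2c1c(-c1ccco1)cn2[C@@H]1O[C@H](CO)[C@@H](O)[C@H]1O` — compound 3 gives > 15000 nM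

Among the measured compounds shown here, compound 1 is the one compound with a number in this assay. For compound 2 the assay reports only a limit, > 20000 nM. For compound 3 the assay likewise reports only a limit, > 15000 nM.

The step from compound 1 to compound 2 is amino in place of hydrogen on an aromatic carbon. In this assay it gives an at least 1.4-fold higher number from compound 1 to compound 2 (0.15 log units; that floor lies within the scatter). Only the floor of this step is known because compound 2 sits at the limit of > 20000 nM in this assay, at which 1 of the 3 values shown sits.

Compound 4 `Nc1nc2c(c(-c3ccco3)cn2[C@@H]2O[C@H](CO)[C@@H](O)[C@H]2O)c(=O)[nH]1` has not been measured. It differs from compound 3 by amino in place of hydrogen on an aromatic carbon. This is the same kind of change as from compound 1 to compound 2, though the surroundings are not identical: in compound 1 the carbon is meta to a methoxy group (2 heavy atoms), whereas in compound 3 it is meta to a group of 1 heavy atom. How the core of compound 1 and the core of compound 3 differ is not broken down here.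

Compound 3 already sits at the limit of > 15000 nM in this assay, at which 1 of the 3 values shown sits, and the earlier step was toward a higher number. For compound 4 the expected step is therefore a step that the limit leaves unreadable from compound 3 to compound 4. Compound 4 is expected to give about 30000 nM in this assay, between 15000 nM and 80000 nM, and most likely the assay will again report only a limit.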

Compound 4, half-maximal inhibitory concentration: > 20000 nM
Compound 4 ended at the assay's limit; the forecaster's own chance of this, stated with the estimate: 85%; the middle value is on the limit's open side.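

In this assay compound 3 and compound 4 both give only limits, so no size can be read for the step between them, amino in place of hydrogen on an aromatic carbon. The compounds shown leave open whether this change moves the number at all on either core, as compound 2, compound 3 and compound 4 all lack a measured number.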